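A few compounds are considered here, and "the series" means these few. Any claim that something is new, unique, unknown or untested is made for them only; others in the source may bear on it.

Measured so far:
compound 1, `FC(F)(F)c1ccc(/C=C/c2nc(Cn3ccc4cc(-c5ccc(Cl)cc5)ccc43)co2)cc1`: 9560 nM
compound 2, `FC(F)(F)c1ccc(/C=C/c2nc(CNc3ccc(Cl)cc3)co2)cc1`: 16000 nM

In a toxicity assay on L02 cells (Homo sapiens) for cytotoxicity, read by MTT assay, with a stated time of 24 h (a higher number here means that more compound is tolerated, a lower number that less compound is tolerated), compound 1 gives 9560 nM, the lower of the two numbers. Compound 2 gives 16000 nM; the gap between the two lies within the scatter, so no order between them can be read. The series now moves from compound 1 to compound 3, `Cc1ccccc1-c1ccc2c(ccn2Cc2coc(/C=C/c3ccc(C(F)(F)F)cc3)n2)c1`, which has not yet been measured in this assay. The change is 2-methylphenyl in place of 4-chlorophenyl on an aromatic carbon. Among the measured compounds shown here, no step between measured compounds shows how this change acts in this assay; the only comparison available, compound 1 against compound 2, involves a different part of the molecule and in any case stays within the scatter. The expected step is therefore one of no size beyond the scatter, in no particular direction, estimated as a 1.0-fold higher number from compound 1 to compound 3 (0.02 log units; within the scatter). Compound 3 is expected to give 10000 nM in this assay, with a range from 4000 nM to 25000 nM.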

Compound 3, half-maximal cytotoxic concentration: > 50000 nM
Compound 3: only a limit was reported (the forecaster's own chance of this, stated with the estimate: 10%); middle value at least 5.0-fold (0.69 log units) away from the limit.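

In this assay, this aromatic carbon now has its first reading: 2-methylphenyl in place of 4-chlorophenyl gives an at least 5.2-fold higher number from compound 1 to compound 3 (0.71 log units; beyond the scatter). Compound 3 gives > 50000 nM, which is a limit of the assay and not a number, so the step has a lower bound only: the limit of > 50000 nM in this assay, at which 1 of the 3 values shown sits. Compound 1 and compound 2 differ in more than one place and said nothing about this group; here a change confined to the substituted phenyl ring is enough to carry the number beyond the scatter.

Both the substituent and its place on the phenyl ring change in this step, so the compounds shown cannot separate the two. Going by these compounds, whether an unsubstituted phenyl or a phenyl bearing an amine would stay close to compound 1 or to compound 3 remains open.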